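This account rests on a few compounds, and the source may have more. Where it says the series, first, only, none or still open, it means among the compounds named here.

Compound 1 `COC(=O)/C=C/c1cccc(N(Cc2ccc(/C=C/c3ccccn3)cc2)C(=O)C2CCCCC2)c1`: 309 nM
Compound 2 `COC(=O)/C=C/c1cccc(N(Cc2ccc(-c3ccc(F)c(Cl)c3)cc2)C(=O)C2CCCCC2)c1`: 66 nM
Compound 3 `COC(=O)/C=C/c1cccc(N(Cc2ccc(-c3c(OC)cccc3OC)cc2)C(=O)C(C)C)c1`: 95 nM

In an assay on isolated protein with Bile acid receptor (Homo sapiens) as the target (a lower number here means that less compound is needed, a higher number that more compound is needed for the effect), compound 2 holds the lowest of the three numbers. Its gap to compound 3 is within the scatter, so no order between those two can be read; compound 1 stands apart, as the step of a 4.7-fold lower number from compound 1 to compound 2 (0.67 log units; beyond the scatter) records.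

Compound 4 `COC(=O)/C=C/c1cccc(N(Cc2ccc(/C=C/C(=O)NC(C)(C)C)cc2)C(=O)C2CCCCC2)c1` differs from compound 2 at the aromatic carbon that carries the aryl ring: 2-((tert-butyl)carbamoyl)ethenyl in place of 3-chloro-4-fluorophenyl on an aromatic carbon. Within the data shown here, the one measured step that bears on this place is a 4.7-fold lower number from compound 1 to compound 2 (0.67 log units; beyond the scatter), in which a 2-(pyridin-2-yl)ethenyl chain at this position gave the higher number and the 3-chloro-4-fluorophenyl ring the lower. Compound 4 again carries an ethenyl chain there, so the expectation is a move back toward the number of compound 1, a modest rise beyond the scatter, a 3.8-fold higher number from compound 2 to compound 4 (0.58 log units; beyond the scatter). For compound 4 in this assay the estimate is 250 nM, with a range from 90 nM to 700 nM.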

Compound 4, half-maximal effective concentration: > 1000 nM
Compound 4: a limit, no number; the forecaster's own chance of this, stated with the estimate: 3%; at least 4.0-fold (0.60 log units) between middle value and limit.
By their numbers in this assay, from the lowest: compounds 2 and 3 (each within the scatter of the next); then compound 1. At a limit, above all of these: compound 4.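

In this assay compound 4 gives a limit and not a number: the limit of > 1000 nM in this assay, at which 1 of the 4 values shown sits.

Replacing the 3-chloro-4-fluorophenyl ring with the 2-((tert-butyl)carbamoyl)ethenyl chain, on the aromatic carbon para to a large group, is a large step, an at least 15-fold higher number from compound 2 to compound 4 (1.18 log units; beyond the scatter), so this position is sensitive to the group it carries. With the ethenyl chain kept, exchanging only its end group still gives a step beyond the scatter, an at least 3.2-fold higher number from compound 1 to compound 4 (0.51 log units; beyond the scatter), so the ethenyl chain alone does not fix the number here.

Going by these compounds, the true size of both steps stays unknown, since each rests on a limit. Also open, on these data alone, is where a carboxylic acid or an amine at the end of the ethenyl chain would fall relative to pyridin-2-yl and (tert-butyl)carbamoyl.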